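Swapping chloro for fluoro on a protein-binding series

The compounds below may be only part of what the source reports. "The series", "measured", "known", "first", "only" and "open" are said of these compounds alone.

Of the compounds shown here, three with a shared core have been measured in an ADME assay on the whole organism (plasma, Macaca fascicularis) for protein binding, read by LC-MS, using equilibrium dialysis and cassette dosing, with a stated time of 24 h, at a dose of 1 mg/kg by the oral route; a lower number here means a smaller unbound share, a higher number a larger unbound share of the compound. Compound 1, `C[C@H](c1ccc(-c2cc(Cl)ccc2-c2nc(=O)o[nH]2)cc1)N(CC1CC1)c1nc2c(C(=O)O)cccc2o1`, gives 0.000108. Compound 2, `CCCCN(c1nc2c(C(=O)O)cccc2o1)[C@H](C)c1ccc(-c2cc(Cl)ccc2-c2nc(=O)o[nH]2)cc1`, gives 0.000135, and compound 3, `CCCCN(c1nc2c(CO)cccc2o1)[C@H](C)c1ccc(-c2ccccc2-c2nnn[nH]2)cc1`, gives 0.00112. Compound 1 therefore sits at the low end of the measured range: compound 2 lies within the scatter of it, since a 1.3-fold higher number from compound 1 to compound 2 (0.10 log units; within the scatter), while compound 3 shows a far larger unbound share, though compound 3 differs from compound 1 in several places at once, so no single step can be read from that pair.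

Compound 4, `C[C@H](c1ccc(-c2cc(F)ccc2-c2nc(=O)o[nH]2)cc1)N(CC1CC1)c1nc2c(C(=O)O)cccc2o1`, is not yet measured. It differs from compound 1 in one place: fluoro in place of chloro on an aromatic carbon. For the measured compounds named here, the only single-place step in the data, the exchange of cyclopropyl for propyl on the chain carbon bound to the ring nitrogen, concerns a different part of the molecule and stayed within the scatter. Nothing measured here touches the halogen on the aromatic ring. The exchange of one halogen atom for another, with no change in donors, acceptors or charge, is expected to move the unbound share little, if at all, in this assay, so the step of a 1.4-fold higher number from compound 1 to compound 4 (0.14 log units; within the scatter) is estimated to stay within the scatter. Compound 4 is expected to give about 0.00015, within a range from 0.00007 to 0.00035.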

Compound 4, unbound fraction: 0.0000977
Beside the measured number, compound 4's estimate is 1.5-fold (0.19 log units) above it; the measured number falls inside the stated range.
By their numbers in this assay, from the lowest: compounds 4, 1 and 2 (each within the scatter of the next); then compound 3.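

In this assay, for the compounds shown here, the halogen on the aromatic carbon, meta to a large group and para to a group of 6 heavy atoms, is changed here for the first time in a single-place step, and the exchange gives a 1.1-fold lower number from compound 1 to compound 4 (0.04 log units; within the scatter). On this core, then, fluoro and chloro at this position cannot be told apart by the unbound fraction, and this position joins the chain on the nitrogen, where the other single-place step gives a 1.3-fold higher number from compound 1 to compound 2 (0.10 log units; within the scatter), as a second place where one change stays within the scatter. Nothing available here explains this result.

The compounds shown leave open whether a group of a different kind at this position, such as a nitrile, a methoxy group or an amine, would move the unbound fraction beyond the scatter, since only two halogens have been compared there. They also leave open whether the same exchange of chloro for fluoro would stay within the scatter on a core carrying a hydroxymethyl group instead of the carboxylic acid.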